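Fluoro on the pendant phenyl of compound 1

The source may report more compounds than this note shows. Statements on the series, on what has been measured and on what is new or still open speak of the compounds shown alone.

Measured so far:
compound 1 `CCN(Cc1ccc(C)cc1)C(=O)c1nc(-c2ccccc2)c2ccccc2n1` — 2.57 nM
compound 2 `CCN(Cc1ccc(O)cc1)C(=O)c1nc(-c2ccccc2)c2ccccc2n1` — 8.76 nM

In an assay on cell membranes from kidney for displacement of a labelled ligand from Translocator protein (Rattus norvegicus) (on this read-out lower numbers stand for stronger inhibition and higher numbers for weaker inhibition), compound 1 gives 2.57 nM, the lowest of the two numbers shown. For the measured compounds named here, the single measured step is a 3.4-fold higher number from compound 1 to compound 2 (0.53 log units; beyond the scatter), a change on the benzylic ring. Compound 3 `CCN(Cc1ccc(C)cc1)C(=O)c1nc(-c2ccccc2F)c2ccccc2n1` differs from compound 1 by fluoro in place of hydrogen on an aromatic carbon. Going by the values given here, that difference sits on the other aromatic ring, so the hydroxy-for-methyl step gives no direct guidance; no measured step bears on this change. Expected: no step beyond the scatter, a 1.0-fold lower number from compound 1 to compound 3 (0.01 log units; within the scatter). Compound 3 is estimated at 2.5 nM, range 1 nM to 6.5 nM.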

Compound 3, inhibition constant: 0.6 nM
The estimate for compound 3 lay 4.2-fold (0.62 log units) above the measured number; measured number below the stated range.
By their numbers in this assay, from the lowest: compound 3; then compound 1; then compound 2.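

The 2-fluorophenyl ring of compound 3 shows that the phenyl on the core, unchanged between compounds 1 and 2, also responds to substitution: in this assay there is a 4.3-fold lower number from compound 1 to compound 3 (0.63 log units; beyond the scatter). A single fluoro ortho to a large group is enough to move the number beyond the scatter. Nothing on hand explains this step.

On these data alone, whether the step is specific to fluoro or to this place on the ring remains open; chloro or methoxy on the same carbon would test the first. Also open, as far as these compounds go, is whether fluoro gives a similar step alongside the hydroxy of compound 2.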